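Compound 3 to compound 4: swapping the ring-carbon side chain

This account rests on a few compounds, and the source may have more. Where it says the series, first, only, none or still open, it means among the compounds named here.

In a functional assay on the whole organism with Mus musculus as the target (on this read-out higher numbers stand for an effect only at larger amounts of compound and lower numbers for an effect already at smaller amounts), compound 3 `COC(=O)/C=C\C1(C)Cc2c(C)c(N)c(C)c(C)c2O1` gives > 100 mg/kg, which is a limit and not a number. This places it at the limit of > 100 mg/kg in this assay, at which 1 of the 3 values shown sits. Compound 1 `COCC1(C)Cc2c(C)c(N)c(C)c(C)c2O1` gives 20.1 mg/kg and compound 2 `Cc1c(C)c2c(c(C)c1N)CC(C)(Cn1ccnc1)O2` gives 25 mg/kg, and a 1.2-fold higher number from compound 1 to compound 2 (0.09 log units; within the scatter) shows that methoxymethyl and (1H-imidazol-1-yl)methyl read alike here.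

The change under study leads to compound 4 `Cc1c(C)c2c(c(C)c1N)CC(C)(CCN(C)C)O2`: 2-(dimethylamino)ethyl in place of 2-(methoxycarbonyl)ethenyl on a saturated ring carbon. In words, 2-(dimethylamino)ethyl stands in place of 2-(methoxycarbonyl)ethenyl on a saturated ring carbon, next to the ring oxygen.

Within the data shown here, two measured steps bear on this, both at the same place and both involving the group that leaves: an at least 4.9-fold higher number from compound 1 to compound 3 (0.69 log units; beyond the scatter) and an at least 4.0-fold higher number from compound 2 to compound 3 (0.60 log units; beyond the scatter). Both lie beyond the scatter, and both are bounded on one side only. Among the measured compounds shown here, no measured compound carries 2-(dimethylamino)ethyl, so the return is an expectation from two side chains only and may be partial.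

Expected in this assay is an at least 3.3-fold lower number from compound 3 to compound 4 (0.52 log units; beyond the scatter), towards a lower number and beyond the scatter. For compound 4 the estimated value is 30 mg/kg, with an expected range from 10 mg/kg to 90 mg/kg.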

Compound 4, dose for 50% inhibition: 19 mg/kg
Estimate against measurement, compound 4: 1.6-fold (0.20 log units) above; low and high end bracket the measured number.
By their numbers in this assay, from the lowest: compounds 4, 1 and 2 (each within the scatter of the next). At a limit, above all of these: compound 3.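

In this assay compound 3 gives > 100 mg/kg, which is a limit and not a number. With 2-(dimethylamino)ethyl in place of 2-(methoxycarbonyl)ethenyl on the saturated ring carbon, the series shows an at least 5.2-fold lower number from compound 3 to compound 4 (0.72 log units; beyond the scatter), so a change of side chain at this place alone is enough to bring the read-out from that limit back among the measured numbers. The new side chain also reads alike with the two earlier ones, with a 1.3-fold lower number from compound 2 to compound 4 (0.12 log units; within the scatter) and a 1.1-fold lower number from compound 1 to compound 4 (0.02 log units; within the scatter), so the methoxy, 1H-imidazol-1-yl and dimethylamino ends all lie within the scatter of one another, and among the four compounds only the 2-(methoxycarbonyl)ethenyl of compound 3 stands apart.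

From the compounds shown here alone, it remains open whether the separation of compound 3 goes with the ester or with the double bond of its side chain, a question that a saturated 2-(methoxycarbonyl)ethyl group or a 2-carboxyethenyl group on the same carbon would address. Going by these compounds, it also remains open how far this flat stretch extends, for example to a longer chain ending in dimethylamino, to a primary amine or to a simple hydroxymethyl group at this place.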